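The source may hold more compounds than are shown below. What is called first, only, known or untested is meant among the compounds shown, and "the series" means these compounds.

Compound 2, with the structure `O=C(Nc1cc(C(F)(F)F)ccc1Nc1ccc(Br)cc1)c1ccncc1`, was tested in a functional assay on Jurkat cells (Homo sapiens) for cytotoxicity, read by MTT assay, with a stated time of 48 h (a higher number here means a weaker inhibitor, a lower number a stronger inhibitor), and came back as "not active" (no number reported), so no single number stands for it. It is not alone in that: compound 1, with the structure `O=C(Nc1cc(C(F)(F)F)ccc1N1CCCC1)c1cccnc1Cl`, was also reported in this assay as "not active" (no number reported). For the measured compounds named here, the only compound of this group with a number is compound 3, with the structure `O=C(Nc1cc(C(F)(F)F)ccc1Nc1ccc(Br)cc1)c1ccccc1`, which in this assay gives 33800 nM, a weak result. Compound 4, with the structure `CCN(CC)c1ccc(C(F)(F)F)cc1NC(=O)c1ccncc1`, has not yet been measured. Its difference from compound 2 is diethylamino in place of (4-bromophenyl)amino on an aromatic carbon. Going by the values given here, there is no measured step between two compounds that would show what this exchange does on its own, so the expectation rests on the standing of compound 2 and compound 1, neither of which yielded a number, and on the weak value of compound 3. On that basis compound 4 is expected to be a weak inhibitor at best, with a fair chance that this assay again reports no number for it. The estimate for compound 4 is 60000 nM, within a range from 15000 nM to 250000 nM.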

Compound 4, half-maximal inhibitory concentration: "not active" (no number reported)
No number was reported for compound 4, and the estimate cannot be compared.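

In this assay compound 2 and compound 4 both came back without a number, so no step can be read between them. Nothing shown here offers an explanation for this result. The compounds shown leave open what diethylamino in place of (4-bromophenyl)amino does on its own.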